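The compounds below may be only part of what the source reports. "The series", "measured", "known", "first", "only" and "open" are said of these compounds alone.

Of the compounds shown here, three from one series have been tested in a functional assay on ileum for inhibition of histamine H1 receptor (Cavia porcellus); a higher number here means a weaker inhibitor, a lower number a stronger inhibitor. Compound 1 `CCNCCn1c(N2CCN(C)CC2)nc2ccccc21` gives 290 nM in this assay. Compound 2 `C=CCOCCn1c(N2CCCN(C)CC2)nc2ccccc21` gives 10 nM in this assay, so of the two numbers shown, compound 1 has the higher one, and the gap between the two lies beyond the usual scatter of repeated measurements. Compound 3 `CCOCCn1c(N2CCN(C(c3ccccc3)c3ccccc3)CC2)nc2ccccc21` is a different case: in this assay it reaches only a limit, > 3000 nM, and no number can be read from it. That is the limit of > 3000 nM in this assay, at which 1 of the 3 values shown sits, and it is the only such case among the three.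

Compound 4 `CN1CCN(c2nc3ccccc3n2CCOCCO)CC1` has not been measured yet. It differs from compound 1 in one place: 2-hydroxyethoxy in place of ethylamino on a saturated chain carbon, two bonds along the chain from an aromatic nitrogen. For the measured compounds named here, no pair of measured compounds differs by exactly this change, so nothing in the data shows how large a step it brings. The expectation here is a modest step from compound 1 to compound 4 toward a lower number, of a 1.9-fold lower number from compound 1 to compound 4 (0.29 log units; within the scatter), though a result within the scatter would not surprise. Compound 4 is therefore estimated to give about 150 nM in this assay, within a range from 40 nM to 600 nM.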

Compound 4, half-maximal inhibitory concentration: 42 nM
The estimate for compound 4 lay 3.6-fold (0.55 log units) above the measured number; measured number inside the range.
By their numbers in this assay, from the lowest: compound 2; then compound 4; then compound 1. At a limit, above all of these: compound 3.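

In this assay, 2-hydroxyethoxy in place of ethylamino on a saturated chain carbon, two bonds along the chain from an aromatic nitrogen, gives a 6.9-fold lower number from compound 1 to compound 4 (0.84 log units; beyond the scatter). For the compounds shown here, this is the first comparison that isolates a single place, and it shows that the number in this assay responds to what this chain carries, which the earlier compounds, each differing from the others in more than one place, could not show on their own. It also shows that a number lower than that of compound 1 is possible with no nitrogen in this part of the chain, although nothing measured here explains why the step runs in this direction.

On these data alone, the swap replaces a whole group at once, so it remains open whether the chain oxygen, the hydroxy group at the chain end or the greater length of the chain accounts for the step, and a 2-methoxyethoxy or a 3-hydroxypropoxy group at the same place would help to tell these apart. As far as these compounds go, it also remains open whether the same swap would bring a step of similar size on a compound with a different group on the other side of the shared core.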